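The source may report more compounds than this note shows. Statements on the series, on what has been measured and on what is new or still open speak of the compounds shown alone.

Compound 1, with the structure `COc1cc(/C=C/C(=O)/C=C(O)/C=C/c2ccc(OC(=O)C(C)(CO)CO)c(OC)c2)ccc1OC(=O)C(C)(CO)CO`, gives 2670 nM in a functional assay on MDA-MB-231 cells (Homo sapiens) for antiproliferative activity, read by MTT assay, with a stated time of 72 h; a lower number here means a stronger inhibitor, a higher number a weaker inhibitor. Compound 2, `COc1cc(/C=C/C(O)=C/C(=O)/C=C/c2ccc(OC(=O)C(C)(CO)CO)c(OC)c2)ccc1O`, gives 5940 nM in this assay, so the step of a 2.2-fold higher number from compound 1 to compound 2 (0.35 log units; beyond the scatter) follows the change (hydrogen in place of (1,1-bis(hydroxymethyl)ethyl)carbonyl on an oxygen on an aromatic ring). Compound 3, `CC(CO)(CO)C(=O)Oc1ccc(/C=C/C(=O)/C=C(O)/C=C/c2ccc(OC(=O)C(C)(CO)CO)cc2)cc1`, gives 6740 nM in this assay; the difference between its core and the core of compound 1 is not broken down here. Compound 4, `CC(CO)(CO)C(=O)Oc1ccc(/C=C/C(=O)/C=C(O)/C=C/c2ccc(O)cc2)cc1`, is not yet measured; it differs from compound 3 by hydrogen in place of (1,1-bis(hydroxymethyl)ethyl)carbonyl on an oxygen on an aromatic ring, the same change that led from compound 1 to compound 2. Resting on that single earlier step, the step of a 2.1-fold higher number from compound 3 to compound 4 (0.32 log units; beyond the scatter) is expected to resemble a 2.2-fold higher number from compound 1 to compound 2 (0.35 log units; beyond the scatter), since only one example of this change is available. Compound 4 is therefore estimated at 14000 nM, within the range 7000 nM to 30000 nM.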

Compound 4, half-maximal inhibitory concentration: 1330 nM
For compound 4 the middle estimate is 11-fold (1.02 log units) above the measured one; the whole stated range lies above it.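

In this assay the change from ((1,1-bis(hydroxymethyl)ethyl)carbonyl)oxy to hydroxy gave a 5.1-fold lower number from compound 3 to compound 4 (0.70 log units; beyond the scatter) and did not repeat the earlier step on the core of compound 1: the same change on two cores in this assay, a 2.2-fold higher number (0.35 log units; beyond the scatter) from compound 1 to compound 2 and a 5.1-fold lower number (0.70 log units; beyond the scatter) from compound 3 to compound 4, 11-fold (1.05 log units) apart, beyond the scatter of two such steps. The same change therefore moved the number in opposite directions on the two cores, so in this series its result on one core cannot be carried over to the other. With a single step on each core, this does not show which feature of the cores sets the two results apart, nor how the change would read on a further core. The compounds shown leave open how a shorter acetyl ester, or an amine in place of the hydroxy, would read on either core. They also leave open how the fully hydroxy analogue of each core would read, with no (1,1-bis(hydroxymethyl)ethyl)carbonyl left.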